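Chloro for fluoro in a series at the assay limit

The source may hold more compounds than are shown below. What is called first, only, known or untested is meant among the compounds shown, and "the series" means these compounds.

Compound 1 `COc1cc(-n2ncnc2-c2ccc(F)cc2)cc(OC)c1OC` stands nowhere definite on the numbers shown: in a functional assay on K562 cells (Homo sapiens) for antiproliferative activity, read by MTT assay, with a stated time of 72 h (a higher number here means a weaker inhibitor, a lower number a stronger inhibitor), compound 1 gives only the limit > 10000 nM and no number. Compound 2 `COc1cc(-c2ncnn2-c2ccc(Cl)cc2Cl)cc(OC)c1OC` likewise returns the limit > 10000 nM in this assay. Compound 3 `COc1cc(-c2ncnn2-c2cccc([N+](=O)[O-])c2)cc(OC)c1OC` also sits at the limit > 10000 nM in this assay. For the measured compounds named here, all three share the same ceiling, (the limit of > 10000 nM in this assay, at which 3 of the 3 values shown sit), so no step between measured compounds can be set. Compound 4 `COc1cc(-n2ncnc2-c2ccc(Cl)cc2)cc(OC)c1OC` differs from compound 1 by chloro in place of fluoro on an aromatic carbon. With every measured value at the limit, no direction for this change can be read from the series. Compound 4 is therefore expected to stay at the limit, estimated at 15000 nM with a range of 5000 nM to 50000 nM. The expected step that the limit leaves unreadable from compound 1 to compound 4 is within the scatter.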

Compound 4, half-maximal inhibitory concentration: > 10000 nM
Compound 4: only a limit was reported (the forecaster's own chance of this, stated with the estimate: 85%); the middle value does not contradict the limit.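

Compound 1 and compound 4 both give only a limit, so no step can be read for chloro in place of fluoro: the limit of > 10000 nM in this assay, at which 4 of the 4 values shown sit.

The compounds shown leave open whether any substitution on this core gives a readable value.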